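Adding a methyl to the hydroxy of compound 3

A few compounds are considered here, and "the series" means these few. Any claim that something is new, unique, unknown or untested is made for them only; others in the source may bear on it.

Compound 1 `CCCCCCCCCCCCCCCCCC(=O)CCCCCOP(=O)(O)OC[C@H](N)C(=O)O`: > 10000 nM, a limit
Compound 2 `CCCCCCCCCCCCCCCCCC(=O)OC[C@H](COP(=O)(O)OC[C@H](N)C(=O)O)OC`: 2000 nM
Compound 3 `CCCCCCCCCCCCCCCCCC(=O)OC[C@H](O)COP(=O)(O)OC[C@H](N)C(=O)O`: 1000 nM

All three compounds were tested in a functional assay on cells (Mast cell, Rattus norvegicus, strain Wistar) for activation, read by fluorescence, with a stated time of 15 min; a higher number here means that more compound is needed for the effect, a lower number that less compound is needed. For compound 1 the assay reports only a limit, > 10000 nM. That leaves two numbers. Compound 3 gives 1000 nM and compound 2 gives 2000 nM, and these two lie within the usual scatter of each other, so compound 3 stands level with compound 2.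

Compound 4 `CCCCCCCCCCCCCCCCCC(=O)OC[C@@H](COP(=O)(O)OC[C@H](N)C(=O)O)OC` has not yet been measured. It departs from compound 3 by methyl in place of hydrogen on an oxygen on a saturated carbon, which turns hydroxy to methoxy.

Among the measured compounds shown here, no measured pair isolates this change, so its size can only be judged indirectly. Compound 2 also carries a methoxy group, and its value of 2000 nM stays within the scatter of compound 3. On that basis, no step beyond the scatter is expected in this assay, though a slight drift toward a higher number would not surprise. The expected change is a 1.5-fold higher number from compound 3 to compound 4 (0.18 log units; within the scatter). In this assay the estimated value for compound 4 is 1500 nM, with an expected range from 400 nM to 6000 nM.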

Compound 4, half-maximal effective concentration: 5000 nM
Beside the measured number, compound 4's estimate is 3.3-fold (0.52 log units) below it, and the stated range covers the measured number.
By their numbers in this assay, from the lowest: compounds 3 and 2 (each within the scatter of the next); then compound 4. At a limit, above all of these: compound 1.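

In this assay the change from hydroxy to methoxy now has a measured size of its own (a 5.0-fold higher number from compound 3 to compound 4 (0.70 log units; beyond the scatter)), so methyl in place of hydrogen on an oxygen on a saturated carbon is a step beyond the scatter at this place. Compounds 2 and 4 have the same atoms and bonds, and a stereocentre at a saturated chain carbon drawn R in compound 2 and S in compound 4 goes with a second modest step (a 2.5-fold higher number from compound 2 to compound 4 (0.40 log units; beyond the scatter)), so the methoxy compounds are not interchangeable in this assay. That second step needs a caveat, as the two drawings are not equally defined: the fact that one of compounds 2 and 4 is drawn with a defined configuration and the other without, at the place where they differ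

The compounds shown leave open whether an ethyl group or a longer chain on this oxygen would move the number further in the same direction, and whether an amine in place of the hydroxy would hold it near the value of compound 3. They also leave open how a hydroxy compound with the other configuration at this carbon would read in this assay and so whether the configuration counts without the methyl.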